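This account rests on a few compounds, and the source may have more. Where it says the series, first, only, none or still open, it means among the compounds named here.

Compound 2 `Cc1ccc(NC(=S)NC(=O)Nc2ccc3c(c2)C(=O)C(=O)N3Cc2ccccc2Cl)cc1` gives 3.73 in a physicochemical assay for lipophilicity, in phosphate buffer, measured as octanol-water partition (on this read-out lower numbers stand for lower lipophilicity and higher numbers for higher lipophilicity), the higher of the two numbers recorded so far, with compound 1 `COc1cccc(NC(=S)NC(=O)Nc2ccc3c(c2)C(=O)C(=O)N3Cc2ccccc2)c1` at 2.4 in this assay, a gap beyond the usual scatter. Compound 3 `COc1cccc(NC(=S)NC(=O)Nc2ccc3c(c2)C(=O)C(=O)N3Cc2ccccc2Cl)c1` differs from compound 2 by the change (3-methoxyphenyl in place of 4-methylphenyl on an amide-type nitrogen). Among the measured compounds shown here, no measured pair shows this change on its own; it is expected to lower the partition coefficient by a moderate step in this assay, so that from compound 2 to compound 3 a number 0.53 log units lower from compound 2 to compound 3 (beyond the scatter) is estimated. Compound 3 is accordingly expected at 3.2, within a range from 2.7 to 3.7.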

Compound 3, partition coefficient: 3.19
Beside the measured number, compound 3's estimate is 0.01 log units above it, and the stated range covers the measured number.
By their numbers in this assay, from the lowest: compound 1; then compound 3; then compound 2.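

In this assay, 3-methoxyphenyl in place of 4-methylphenyl on an amide-type nitrogen gives a number 0.54 log units lower from compound 2 to compound 3 (beyond the scatter) with the chloro group held constant. Chloro in place of hydrogen on an aromatic carbon gives a number 0.79 log units higher from compound 1 to compound 3 (beyond the scatter) with 3-methoxyphenyl held constant, so each change now has a step of its own. Nothing available explains either step.

Going by these compounds, what a carboxylic acid or an amine in place of the methoxy group would give in this assay stays open. So does whether the chloro step carries over when 4-methylphenyl is present.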